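Lactam ring size and solubility across two cores

The source may report more compounds than this note shows. Statements on the series, on what has been measured and on what is new or still open speak of the compounds shown alone.

Compound 1 `C[C@]1(CS(=O)(=O)N2CC=C(C#Cc3cccc(N4CCCC4=O)c3)CC2)NC(=O)NC1=O` gives 94000 nM in a physicochemical assay for solubility, at pH 7.4; a higher number here means a more soluble compound, a lower number a less soluble compound.
Compound 2 `C[C@]1(CS(=O)(=O)N2CC=C(C#Cc3cccc(N4CCCCC4=O)c3)CC2)NC(=O)NC1=O` gives 89000 nM in this assay.
Compound 3 `O=C1CCCN1c1cnc(NCc2c(F)ccc3c2CCO3)c2cn[nH]c(=O)c12` gives 66000 nM in this assay.

Compounds 1 and 2 share one core and differ in a single place: 2-oxopiperidin-1-yl in place of 2-oxopyrrolidin-1-yl on an aromatic carbon. That change made a 1.1-fold lower number from compound 1 to compound 2 (0.02 log units; within the scatter), so the two numbers cannot be told apart with confidence.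

Compound 4 `O=C1CCCCN1c1cnc(NCc2c(F)ccc3c2CCO3)c2cn[nH]c(=O)c12` has not yet been measured. It stands to compound 3 as compound 2 stands to compound 1, with the same kind of change: 2-oxopiperidin-1-yl in place of 2-oxopyrrolidin-1-yl on an aromatic carbon. The surroundings are not identical, though. In compound 1 the group sits on an aromatic carbon of a six-membered aromatic ring of carbon only, meta to a large group; in compound 3 it sits on a six-membered aromatic ring with one nitrogen, part of a fused system, ortho and meta to a fused ring. The difference between the two cores themselves is not broken down here.

Because the earlier step was a 1.1-fold lower number from compound 1 to compound 2 (0.02 log units; within the scatter), only a small step is expected here, a 1.1-fold lower number from compound 3 to compound 4 (0.04 log units; within the scatter). Compound 4 is therefore estimated at 60000 nM, likely between 30000 nM and 120000 nM.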

Compound 4, solubility: 18000 nM
For compound 4 the middle estimate is 3.3-fold (0.52 log units) above the measured one, and the stated range ends above it.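

In this assay, placing 2-oxopiperidin-1-yl where 2-oxopyrrolidin-1-yl stood gave a 3.7-fold lower number from compound 3 to compound 4 (0.56 log units; beyond the scatter), whereas the same exchange on the other core gave a 1.1-fold lower number from compound 1 to compound 2 (0.02 log units; within the scatter), so the size of this step did not carry over from the core of compound 1 to the core of compound 3. Within the data shown here, this shows that a near-silent change on one core can be a poor guide to the same change on another, but with only one pair on each core it does not show a general rule for either core. Nothing available here explains why the two pairs differ.

As far as these compounds go, it remains open how a dimethylamino group or a carboxylic acid at the same place on the core of compound 3 would compare with compound 3 and compound 4. A third core carrying the same two groups would also be needed to tell which of the two pairs is the more typical.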